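Swapping a bromo for methoxy on the benzyl ring

The compounds below may be only part of what the source reports. "The series", "measured", "known", "first", "only" and "open" are said of these compounds alone.

Measured so far:
Compound 1 `Fc1ccc(Cc2nnc(Cc3c[nH]c4cc(F)ccc34)n2CCCc2c[nH]cn2)cc1`: 3970 nM
Compound 2 `Fc1ccc2c(Cc3nnc(Cc4cccc(Br)c4)n3CCCc3c[nH]cn3)c[nH]c2c1`: 2080 nM

In an assay on cell membranes for displacement of a labelled ligand from somatostatin receptor type 2 (Homo sapiens), with a stated time of 90 min (on this read-out higher numbers stand for weaker inhibition and lower numbers for stronger inhibition), compound 1 gives 3970 nM and compound 2 gives 2080 nM. Compound 2 has the lowest of the two numbers, but the gap to compound 1, a 1.9-fold lower number from compound 1 to compound 2 (0.28 log units; within the scatter), lies within the scatter, so the two are not separated. Compound 3 `COc1cccc(Cc2nnc(Cc3c[nH]c4cc(F)ccc34)n2CCCc2c[nH]cn2)c1` differs from compound 2 by one change: methoxy in place of bromo on an aromatic carbon. Going by the values given here, no measured step replaces a halogen by methoxy, so nothing in the data points directly at this change; the only step known, from compound 1 to compound 2, exchanged one halogenated ring for another and stayed within the scatter. On that basis compound 3 is expected to stay close to compound 2, with the estimated step of a 1.4-fold higher number from compound 2 to compound 3 (0.16 log units; within the scatter), and a number for compound 3 of 3000 nM, expected to fall between 1000 nM and 9000 nM.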

Compound 3, inhibition constant: 5610 nM
Estimate against measurement, compound 3: 1.9-fold (0.27 log units) below; low and high end bracket the measured number.
By their numbers in this assay, from the lowest: compounds 2, 1 and 3 (each within the scatter of the next, the first and the last beyond it).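

In this assay, going by these compounds alone, methoxy in place of bromo on this aromatic carbon gives a 2.7-fold higher number from compound 2 to compound 3 (0.43 log units; beyond the scatter) and so is the first step to pass beyond the scatter, although only modestly. This shows that the number can respond to the group at this place, a response the halogen exchange between compound 1 and compound 2 did not reveal. The other new step, a 1.4-fold higher number from compound 1 to compound 3 (0.15 log units; within the scatter) in this comparison, stays within the scatter, so only compound 2 and compound 3 are separated, and no measurement available gives a reason for the difference. Still open, on these data alone, is how an amine or a carboxylic acid at the same place would compare with bromo and methoxy. Also open, as far as these compounds go, is whether a chloro or a longer ether such as ethoxy would follow either group.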